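This account rests on a few compounds, and the source may have more. Where it says the series, first, only, none or still open, it means among the compounds named here.

Measured in a toxicity assay on NIH3T3 cells (Mus musculus) for cytotoxicity, read by resazurin assay; a lower number here means that less compound is needed, a higher number that more compound is needed for the effect:
compound 1, `Cc1cccc(-c2cccc(NCc3cncn3Cc3ccccc3)c2)c1C`: > 1000 nM, a limit of the assay rather than a number.
compound 2, `CC(C)OC(=O)c1ccc(NCc2cncn2Cc2ccc(-c3ccccc3)cc2)cc1-c1ccccc1`: > 10000 nM, likewise a limit and not a number.

Compound 1 stands at a limit in this assay, as the limit of > 1000 nM in this assay, at which 1 of the 2 values shown sits, records. Compound 2 also sits at a limit, as the limit of > 10000 nM in this assay, at which 1 of the 2 values shown sits, shows. Both values are limits, so no order between the two compounds can be read from them. Compound 3, `c1ccc(Cn2cncc2CNc2cccc(-c3cccnc3)c2)cc1`, is not yet measured. It arises from compound 1 by pyridin-3-yl in place of 2,3-dimethylphenyl on an aromatic carbon. The step is expected to be none beyond the scatter, a step that the limit leaves unreadable from compound 1 to compound 3, so compound 3 would likely again give only a limit. Compound 3 is estimated at 5000 nM, with a range from 1000 nM to 30000 nM.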

Compound 3, half-maximal effective concentration: > 1000 nM
Compound 3 was reported as a limit; the forecaster's own chance of this, stated with the estimate: 85%; the middle value is on the limit's open side.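

Compound 1 and compound 3 both stand only as limits in this assay, so no step can be read between them. The compounds shown leave open whether pyridin-3-yl in place of 2,3-dimethylphenyl changes the read-out at all.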